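From tert-butyl to trifluoromethyl on the sulfonamide nitrogen's ring

The source may report more compounds than this note shows. Statements on the series, on what has been measured and on what is new or still open speak of the compounds shown alone.

Measured so far in a functional assay on Huh-7 cells (Homo sapiens) for inhibition, read by CCK-8 assay, with a stated time of 72 h; on this read-out lower numbers stand for stronger inhibition and higher numbers for weaker inhibition:
compound 1 `Cc1ccc(C)c(NS(=O)(=O)c2cccc(CCCCCCNC(=O)/C=C/c3cccnc3)c2)c1` gives 2.58 nM
compound 2 `CCc1ccc(NS(=O)(=O)c2cccc(CCCCCCNC(=O)/C=C/c3cccnc3)c2)cc1` gives 34.6 nM
compound 3 `CC(C)(C)c1ccc(NS(=O)(=O)c2cccc(CCCCCCNC(=O)/C=C/c3cccnc3)c2)cc1` gives 163 nM

Compound 3 stands at the top of these numbers, with 163 nM as the highest of the three. Compound 4 `O=C(/C=C/c1cccnc1)NCCCCCCc1cccc(S(=O)(=O)Nc2ccc(C(F)(F)F)cc2)c1` differs from it in one group: trifluoromethyl in place of tert-butyl on an aromatic carbon is trifluoromethyl in place of tert-butyl on an aromatic carbon, para to a large group. Among the compounds with values here, no measured step makes this exact exchange. The closest is a 4.7-fold higher number from compound 2 to compound 3 (0.67 log units; beyond the scatter) for ethyl giving way to tert-butyl on the same aromatic carbon, a modest step beyond the scatter. The steps of a 13-fold higher number from compound 1 to compound 2 (1.13 log units; beyond the scatter) and a 63-fold higher number from compound 1 to compound 3 (1.80 log units; beyond the scatter) are large, but they start from a differently substituted group on the sulfonamide nitrogen and so bear less directly. In this assay, within the data shown here, a modest step towards a lower number is therefore expected, though no measured compound yet carries trifluoromethyl. The expected change is a 2.3-fold lower number from compound 3 to compound 4 (0.37 log units; beyond the scatter) on this estimate. For compound 4 the estimated value is 70 nM with an expected range from 20 nM to 250 nM in this read-out.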

Compound 4, half-maximal inhibitory concentration: 164 nM
Beside the measured number, compound 4's estimate is 2.3-fold (0.37 log units) below it; the range from low to high includes it.
By their numbers in this assay, from the lowest: compound 1; then compound 2; then compounds 3 and 4 (each within the scatter of the next).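

In this assay, trifluoromethyl and tert-butyl cannot be told apart on this aromatic carbon, para to a large group, with a 1.0-fold higher number from compound 3 to compound 4 (0.00 log units; within the scatter). Ethyl now stands apart from both of these groups at this place, since trifluoromethyl gives a 4.7-fold higher number from compound 2 to compound 4 (0.68 log units; beyond the scatter), matching the step seen with tert-butyl, a 4.7-fold higher number from compound 2 to compound 3 (0.67 log units; beyond the scatter), while the 2,5-dimethylphenyl group remains well separated, with a 64-fold higher number from compound 1 to compound 4 (1.80 log units; beyond the scatter). Nothing available here accounts for this match between tert-butyl and trifluoromethyl.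

The compounds shown leave open whether a methoxy group, a nitrile or a carboxylic acid on the same aromatic carbon would give a number like that of compound 2 or like those of compound 3 and compound 4. They also leave open whether a single methyl group on that ring would approach the number of compound 1.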